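The source may report more compounds than this note shows. Statements on the series, on what has been measured and on what is new or still open speak of the compounds shown alone.

Measured compounds:
compound 1, `COc1ccc(/C=C/C(=O)/C=C/c2ccc(OCc3cn(CCCCOc4cc(=O)oc5ccccc45)nn3)c(OC)c2)cc1OC`, 59%
compound 2, `COc1cc(/C=C/C(=O)/C=C/c2ccccc2)ccc1OCc1cn(CCCCOc2cc(=O)oc3ccccc23)nn1`, 36%
compound 3, `COc1ccc(/C=C/C(=O)/C=C/c2ccc(OCc3cn(CCOc4cc(=O)oc5ccccc45)nn3)c(OC)c2)cc1OC`, 90%

In a functional assay on THP-1 cells (Homo sapiens) for inhibition, read by sulforhodamine B assay, with a stated time of 48 h, tested at 50 uM (a lower number here means less inhibition of growth, a higher number more inhibition of growth at the concentration tested), compound 3 gives 90%, the highest of the three; compound 1 gives 59% and compound 2 gives 36%. The difference between the core of compound 1 and the core of compound 3 is not broken down here.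

Compound 4, `COc1cc(/C=C/C(=O)/C=C/c2ccccc2)ccc1OCc1cn(CCOc2cc(=O)oc3ccccc23)nn1`, is not yet measured in this assay. It differs from compound 3 by phenyl in place of 3,4-dimethoxyphenyl on a double-bonded chain carbon bound to a double-bonded chain carbon. The same change, made from compound 1 to compound 2 as phenyl in place of 3,4-dimethoxyphenyl on a double-bonded chain carbon bound to a double-bonded chain carbon, gave a number 23 percentage points lower from compound 1 to compound 2 (beyond the scatter). Since the place of the change is the same in both pairs, a step of about the same size is expected here, a number 23 percentage points lower from compound 3 to compound 4 (beyond the scatter), resting on a number 23 percentage points lower from compound 1 to compound 2 (beyond the scatter). Compound 4 is therefore estimated at 67% in this assay, expected between 50% and 82%.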

Compound 4, percent growth inhibition at one concentration: 61%
Compound 4: middle estimate off by 6 percentage points, on the high side, within the range that was stated.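

In this assay, phenyl in place of 3,4-dimethoxyphenyl gives a number 29 percentage points lower from compound 3 to compound 4 (beyond the scatter). The change carries over between these two cores with a step of about the same size: the same change on two cores in this assay, a number 23 percentage points lower (beyond the scatter) from compound 1 to compound 2 and a number 29 percentage points lower (beyond the scatter) from compound 3 to compound 4, 6 percentage points apart, within the scatter of two such steps. This supports carrying the step between these two cores only; it does not show that the step would hold on any other core, and it does not separate the contributions of the two methoxy groups.

Still open, on these data alone, is how a phenyl bearing a single methoxy group would fall relative to these pairs. Also open, as far as these compounds go, is whether an aminophenyl or a carboxyphenyl in the same place would follow the same trend.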